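Amino in place of nitro at the assay limit

The source may report more compounds than this note shows. Statements on the series, on what has been measured and on what is new or still open speak of the compounds shown alone.

Of the compounds shown here, three with a shared core have been measured in an ADME assay on L929 cells (Mus musculus) for cytotoxicity, read by resazurin assay, with a stated time of 72 h; on this read-out higher numbers stand for weaker inhibition and lower numbers for stronger inhibition. Compound 1 (`O=C(/C=C/c1ccc2c(c1)B(O)OC2)c1ccco1`) gives > 10 ug/mL, which is a limit of the assay and not a number. Compound 2 (`Cc1cccc(C(=O)/C=C/c2ccc3c(c2)B(O)OC3)c1`) gives 8.56 ug/mL. Compound 3 (`O=C(/C=C/c1ccc2c(c1)B(O)OC2)c1ccc([N+](=O)[O-])cc1`) gives > 10 ug/mL, again only a limit. This is the limit of > 10 ug/mL in this assay, at which 2 of the 3 values shown sit. Compound 4 (`Nc1ccc(C(=O)/C=C/c2ccc3c(c2)B(O)OC3)cc1`) has amino in place of nitro on an aromatic carbon. Going by the values given here, the only measured step, an at least 1.1-fold lower number from compound 1 to compound 2 (0.06 log units; that floor lies within the scatter), swaps a different group, so no step beyond the scatter is expected in this assay. The estimated step is an at least 1.1-fold lower number from compound 3 to compound 4 (0.04 log units; that floor lies within the scatter). For compound 4 the expected value is 9 ug/mL, with an estimated range of 4 ug/mL to 20 ug/mL.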

Compound 4, half-maximal inhibitory concentration: > 10 ug/mL
Compound 4 gave a limit, no number (the forecaster's own chance of this, stated with the estimate: 45%); at least 1.1-fold (0.04 log units) between middle value and limit.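

With amino in place of nitro, para to a large group, compound 4 stays at a limit of the assay, as compound 3 does, so neither group gives a readable number at this position. The steps to compound 4 from compound 1 and compound 3 cannot be read, and the only readable one is an at least 1.1-fold higher number from compound 2 to compound 4 (0.06 log units; that floor lies within the scatter). The limit now holds most of the set: the limit of > 10 ug/mL in this assay, at which 3 of the 4 values shown sit.

Going by these compounds, how far apart compound 3 and compound 4 really lie stays open. So does whether a methoxy or a dimethylamino group at this position would give a number under the limit.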